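The source may report more compounds than this note shows. Statements on the series, on what has been measured and on what is new or still open speak of the compounds shown alone.

Working notes on the series, binding read in an assay on cells with melanin-concentrating hormone receptor 1 (Homo sapiens) as the target, read by radioligand binding; a higher number here means a weaker inhibitor, a lower number a stronger inhibitor.

The shared core carries an alkoxy side chain on the aromatic ring. Compound 1 `COCCOCCOc1cccc2ccc(N)nc12` gives > 2000 nM, which is a limit of the assay, not a number (the limit of > 2000 nM in this assay, at which 1 of the 3 values shown sits). Compound 2 `CCC(C)COc1cccc2ccc(N)nc12` gives 36 nM, the lowest number among the measured members; compound 3 `Nc1ccc2cccc(OCC3CC4CCC3C4)c2n1` gives 137 nM, and the gap from compound 2 to compound 3 lies beyond the scatter. Within the data shown here, no single-point step is computed for that pair. Among the measured compounds shown here, the one measured step is an at least 55-fold lower number from compound 1 to compound 2 (1.74 log units; beyond the scatter), which separates a branched alkyl chain from an ether-containing chain.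

Compound 4 `CC(C)C(C)Oc1cccc2ccc(N)nc12` is the next member, not yet measured. 1,2-dimethylpropyl in place of 2-methylbutyl on an oxygen on an aromatic ring Both groups are branched alkyl chains of the same size; the measured step from compound 1 to compound 2 concerns a different kind of exchange, so it does not bear directly on this one, and no step beyond the scatter is expected in this assay in either direction. Compound 4 is therefore expected to give 50 nM, between 15 nM and 160 nM, an expected change of a 1.4-fold higher number from compound 2 to compound 4 (0.14 log units; within the scatter) from compound 2.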

Compound 4, half-maximal inhibitory concentration: 199 nM
For compound 4 the middle estimate is 4.0-fold (0.60 log units) below the measured one; measured number above the stated range.
By their numbers in this assay, from the lowest: compound 2; then compounds 3 and 4 (each within the scatter of the next). At a limit, above all of these: compound 1.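

In this assay, 1,2-dimethylpropyl in place of 2-methylbutyl gives a 5.5-fold higher number from compound 2 to compound 4 (0.74 log units; beyond the scatter). The earlier measured step set an ether-containing chain against a branched alkyl chain, whereas this one keeps the atoms the same, with 5 carbon heavy atoms, no ring and no hydrogen-bond donors or acceptors on either side. On an oxygen on an aromatic ring, the way these atoms are joined is therefore enough to shift the number beyond the scatter, at least for this one pair. No measured property shown here bears on this step, so it remains without an assigned cause.

The compounds shown leave open how a straight pentyl chain of the same size would read. They also leave open whether a longer alkyl chain or a terminal amine would be tolerated on this oxygen.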